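Swapping Isopropoxy for Methanesulfonamido on the Outer Ring

A few compounds are considered here, and "the series" means these few. Any claim that something is new, unique, unknown or untested is made for them only; others in the source may bear on it.

Compound 1, `CN[C@@H](CC(C)C)CN(C(=O)[C@@H]1C[C@H]1c1ccccc1)c1ccc(-c2ccccc2)cc1`: 2 nM
Compound 2, `CC[C@H](C)[C@H](N)CN(C(=O)[C@@H]1C[C@H]1c1ccc(F)cc1F)c1ccc(-c2ccccc2)cc1`: 1300 nM
Compound 3, `CC[C@H](C)[C@H](N)CN(C(=O)[C@@H]1C[C@H]1c1ccccc1)c1ccc(-c2ccc(OC(C)C)cc2)cc1`: 72 nM

These three compounds were tested in a functional assay for agonist activity at G protein-coupled receptor 88 (Homo sapiens), read by HTRF and cAMP accumulation; a lower number here means that less compound is needed, a higher number that more compound is needed for the effect. Compound 3 stands second highest of the three numbers: compound 2 sits above it and compound 1 below it, and both gaps lie well beyond the usual scatter. Compound 4, `CC[C@H](C)[C@H](N)CN(C(=O)[C@@H]1C[C@H]1c1ccccc1)c1ccc(-c2ccc(NS(C)(=O)=O)cc2)cc1`, differs from compound 3 in one place only: methanesulfonamido in place of isopropoxy on an aromatic carbon. Among the measured compounds shown here, no measured pair shows this same change, so its effect cannot be read from the data. The expectation is a moderate rise in the number, somewhat beyond the scatter, for the step of a 2.8-fold higher number from compound 3 to compound 4 (0.44 log units; beyond the scatter). Compound 4 is therefore expected to give roughly 200 nM, within a range from 40 nM to 1000 nM.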

Compound 4, half-maximal effective concentration: 1200 nM
Beside the measured number, compound 4's estimate is 6.0-fold (0.78 log units) below it, outside the stated range (above it).
By their numbers in this assay, from the lowest: compound 1; then compound 3; then compounds 4 and 2 (each within the scatter of the next).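

At this position on the outer ring, the choice of group clearly matters in this assay: methanesulfonamido in place of isopropoxy gives (a 17-fold higher number from compound 3 to compound 4 (1.22 log units; beyond the scatter)), so the two groups are far from interchangeable here. Among the compounds shown here, this is the first comparison that changes this position alone, as the earlier compounds differ from one another in more than one place. Nothing measured here explains the rise in the number. Still open, from the compounds shown here alone, is whether a methoxy group, an amine or a carboxylic acid at this position would give a number closer to that of compound 3 or that of compound 4.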